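The compounds below may be only part of what the source reports. "The series", "measured", "known", "first", "only" and "open" are said of these compounds alone.

Among the measured compounds shown here, compound 1 `Cc1nc(C#Cc2cc(Br)cc([N+](=O)[O-])c2)cs1` holds the second highest of the three numbers measured so far in an assay on HEK293 cells for displacement of a labelled ligand from metabotropic glutamate receptor 5 (Rattus norvegicus), read by scintillation counting; a higher number here means a weaker inhibitor, a lower number a stronger inhibitor: compound 1 gives 0.93 nM. Its nearest neighbour is compound 3 `Cc1nc(C#Cc2cc(I)cc([N+](=O)[O-])c2)cs1`, which gives 1.84 nM in this assay; the step of a 2.0-fold higher number from compound 1 to compound 3 (0.30 log units; within the scatter). Furthest away is compound 2 `Cc1nc(C#Cc2cc(F)cc([N+](=O)[O-])c2)cs1`, which gives 0.3 nM in this assay; here a 3.1-fold lower number from compound 1 to compound 2 (0.49 log units; beyond the scatter). The two halogen analogues are themselves separated by a larger gap: a 6.1-fold higher number from compound 2 to compound 3 (0.79 log units; beyond the scatter).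

For the measured compounds named here, compound 4 `Cc1nc(C#Cc2cc(Br)cc(Br)c2)cs1` alters compound 1 in a way none of the measured compounds does: bromo in place of nitro on an aromatic carbon. Every measured step exchanges one halogen for another and leaves the nitro group untouched, so none of them bears directly on this change; they only show that single-atom swaps on this ring have moved the number by amounts from within the scatter up to a modest step. Whether giving up the nitro group, with its two hydrogen-bond acceptors, costs affinity cannot be read from the measured compounds. The step from compound 1 to compound 4 is therefore expected to be a 3.2-fold higher number from compound 1 to compound 4 (0.51 log units; beyond the scatter), a modest rise that is far from certain. Compound 4 is estimated to give 3 nM in this assay, with a range from 0.7 nM to 15 nM.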

Compound 4, inhibition constant: 0.69 nM
Compound 4: middle estimate off by 4.3-fold (0.64 log units), on the high side, and the stated range ends above it.
By their numbers in this assay, from the lowest: compound 2; then compounds 4, 1 and 3 (each within the scatter of the next, the first and the last beyond it).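

In this assay, the exchange of nitro for bromo gives a 1.3-fold lower number from compound 1 to compound 4 (0.13 log units; within the scatter), so on this aromatic carbon the nitro group can be given up without a change in the number that stands out from the scatter. The earlier compounds shown here all kept the nitro group and swapped only one halogen for another, so they could not show this; here a group with 3 heavy atoms and 2 hydrogen-bond acceptors gives way to a single bromine atom with no hydrogen-bond acceptors, and the two compounds remain indistinguishable in this measurement. Nothing available explains why these two different groups give such similar numbers.

This single pair leaves open how much freedom this aromatic carbon really allows, since an amine, a carboxylic acid, a nitrile or a longer chain in the same place could behave quite differently from nitro and bromo. As far as these compounds go, it is also open whether the halogen swaps on the other aromatic carbon, seen so far only with the nitro group present, would give steps of the same size in compounds that carry bromo in its place.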